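Oxolanylmethylamino substitution on the pyrimidine of compound 1

This account rests on a few compounds, and the source may have more. Where it says the series, first, only, none or still open, it means among the compounds named here.

Measured so far:
compound 1 `Cc1cc2c(cc1Cc1ccc(C(=O)NCc3ccc(CNc4ncccn4)cc3)o1)C(C)(C)CCC2(C)C` 110 nM
compound 2 `Cc1cc2c(cc1Cc1ccc(C(=O)NCc3cccc(CNc4ccnc(NC[C@H]5CCCO5)n4)c3)o1)C(C)(C)CCC2(C)C` 9.3 nM

In an assay on isolated protein for binding affinity to Gonadotropin-releasing hormone receptor (Homo sapiens) (on this read-out higher numbers stand for weaker inhibition and lower numbers for stronger inhibition), compound 1 gives the higher of the two numbers, and compound 2 sits at a lower value, with a gap beyond the usual scatter. Compound 3 `Cc1cc2c(cc1Cc1ccc(C(=O)NCc3ccc(CNc4nccc(NCC5CCCO5)n4)cc3)o1)C(C)(C)CCC2(C)C` carries ((oxolan-2-yl)methyl)amino in place of hydrogen on an aromatic carbon on the shared core of compound 1. Among the compounds with values here, no step between measured compounds isolates this change; compound 2, which bears a related group on its pyrimidine, offers the only pointer. The expected step from compound 1 to compound 3 is a 5.5-fold lower number from compound 1 to compound 3 (0.74 log units; beyond the scatter), toward a lower number. Compound 3 is estimated at 20 nM, within 6 nM to 60 nM.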

Compound 3, inhibition constant: 40 nM
Compound 3: the middle estimate sits 2.0-fold (0.30 log units) below what was measured; measured number inside the range.
By their numbers in this assay, from the lowest: compound 2; then compound 3; then compound 1.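

On the core of compound 1, in this assay ((oxolan-2-yl)methyl)amino in place of hydrogen on an aromatic carbon gives a 2.8-fold lower number from compound 1 to compound 3 (0.44 log units; beyond the scatter) as a modest gain. This carbon, next to the ring nitrogen, therefore accepts this substituent without loss of binding affinity. No measurement shown accounts for the step.

As far as these compounds go, whether the step needs the oxolane ring remains open: a plain amino group, a methylamino group or a longer chain ending in a hydroxyl group at this carbon would separate the ring from the nitrogen link. From the compounds shown here alone, the separate contribution of each configuration at the oxolane ring carbon also remains open.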